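Swapping a methoxyalkyl chain for a methylbenzyl group

A few compounds are considered here, and "the series" means these few. Any claim that something is new, unique, unknown or untested is made for them only; others in the source may bear on it.

Of the compounds shown here, three have been tested in an ADME assay on RAW264.7 cells (Mus musculus) for cytotoxicity, read by MTT assay, with a stated time of 24 h, in the absence of a further agent; a lower number here means a stronger inhibitor, a higher number a weaker inhibitor. Compound 1, `O=C1OC(Cc2nc(-c3ccc(Oc4ccccc4)cc3)no2)c2ccccc21`, gives only the limit of the measurement, > 40000 nM. Compound 2, `CCC(C)Oc1ccc(C(O)C2OC(=O)c3c(OC)cc(OC)cc32)cc1`, likewise gives only the limit, > 40000 nM. Compound 3, `COCCCOc1ccc(C(O)C2OC(=O)c3c(OC)cc(OC)cc32)cc1`, gives only the limit too, > 40000 nM. Because all three values sit at the limit of > 40000 nM in this assay, at which 3 of the 3 values shown sit, compound 3 cannot be placed relative to the other two; the change a step that the two limits leave unreadable from compound 2 to compound 3 stays unreadable.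

Compound 4, `COc1cc(OC)c2c(c1)C(C(O)c1ccc(OCc3ccc(C)cc3)cc1)OC2=O`, differs from compound 3 in one place: 4-methylphenyl in place of 2-methoxyethyl on a saturated chain carbon bound to an oxygen on an aromatic ring. Going by the values given here, only one measured step shares an anchor with this change, and it is the unreadable one from compound 2 to compound 3, so it offers no size to carry over. Among the compounds with values here, compound 1 shares no step with compound 4 at all. With every measured value resting at the limit, there is no sign of a step in either direction beyond the scatter, and the expectation for compound 4 is again a result at the limit rather than a number. The step of a number no higher from compound 3 to compound 4 (the limit leaves the size open) is therefore estimated as essentially none, with compound 4 expected at 40000 nM, within the range 15000 nM to 100000 nM in this assay.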

Compound 4, half-maximal inhibitory concentration: > 40000 nM
Compound 4: no number, only a limit; the forecaster's own chance of this, stated with the estimate: 85%; the middle value lies on the limit itself.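

In this assay compound 4 gives only a limit, > 40000 nM. Going by these compounds alone, no step from compound 2 or compound 3 to compound 4 can be read, because every value shown is a limit: the limit of > 40000 nM in this assay, at which 4 of the 4 values shown sit. On these data alone, whether changing the group on that oxygen moves the result in this assay at all, and by how much, stays open.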